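Hepatocyte half-life: from sulfonamide to benzamide

The source may report more compounds than this note shows. Statements on the series, on what has been measured and on what is new or still open speak of the compounds shown alone.

Measured in an ADME assay on cells (Hepatocyte, Homo sapiens) for metabolic stability; on this read-out higher numbers stand for a longer-lived compound and lower numbers for a shorter-lived compound:
- Compound 1 `O=C(OC1CCC(CN2CCN(c3cc(=O)c4cc(C(F)(F)F)cc([N+](=O)[O-])c4s3)CC2)CC1)c1ccccc1`: 0.603 h
- Compound 2 `CS(=O)(=O)NC1CCC(CN2CCN(c3cc(=O)c4cc(C(F)(F)F)cc([N+](=O)[O-])c4s3)CC2)CC1`: > 1.55 h (a limit)
- Compound 3 `O=c1cc(N2CCN(CC3CCC(NS(=O)(=O)c4ccccc4)CC3)CC2)sc2c([N+](=O)[O-])cc(C(F)(F)F)cc12`: > 1.55 h (a limit)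

Compound 3 stands at > 1.55 h, which is a limit and not a number. It shares that position with compound 2: the limit of > 1.55 h in this assay, at which 2 of the 3 values shown sit.

Compound 4 `O=C(NC1CCC(CN2CCN(c3cc(=O)c4cc(C(F)(F)F)cc([N+](=O)[O-])c4s3)CC2)CC1)c1ccccc1` differs from compound 3 as follows: benzoyl in place of phenylsulfonyl on an amine nitrogen. Cut one bond further out, the change reads (phenylsulfonyl)amino to benzamido.

Among the measured compounds shown here, no measured step makes this exchange on the amine nitrogen, so the evidence is indirect. Methanesulfonamido in place of benzoyloxy gave an at least 2.5-fold higher number from compound 1 to compound 2 (0.41 log units; beyond the scatter). (Phenylsulfonyl)amino in place of benzoyloxy gave an at least 2.5-fold higher number from compound 1 to compound 3 (0.41 log units; beyond the scatter). For the measured compounds named here, both steps lie beyond the scatter, and both lead from the only compound with a number to a compound with a substituted amine nitrogen on the saturated ring carbon. Phenyl in place of methyl on a sulfonyl sulfur gave a step that the two limits leave unreadable from compound 2 to compound 3, which adds no readable size.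

Compound 4 keeps that amine nitrogen, so no step beyond the scatter is expected in this assay, though this remains an inference across a change not yet tested. The expected step is a step that the limit leaves unreadable from compound 3 to compound 4. For compound 4 the estimate is 1.8 h, with an expected range of 0.9 h to 3.5 h.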

Compound 4, half-life: > 1.55 h
Compound 4 was reported as a limit; the forecaster's own chance of this, stated with the estimate: 60%; the middle value is on the limit's open side.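

In this assay, benzamido in place of benzoyloxy on a saturated ring carbon gave an at least 2.5-fold higher number from compound 1 to compound 4 (0.41 log units; beyond the scatter). Among the compounds shown here, compound 1 and compound 4 both carry the benzoyl group, so this step changes the atom linking that group to the saturated ring carbon, whereas the earlier steps from compound 1 also replaced the benzoyl group with a sulfonyl group. Compound 4 is reported as a limit, so sulfonyl groups are no longer the only groups on this amine nitrogen to reach it, and the steps among compound 2, compound 3 and compound 4 cannot be read: the limit of > 1.55 h in this assay, at which 3 of the 4 values shown sit.

The shown compounds therefore give no order among methanesulfonamido, (phenylsulfonyl)amino and benzamido, and no measure of how far any of them lies past the limit. From the compounds shown here alone, it also remains open whether the same step from oxygen to amine nitrogen would hold with an acetyl group in place of benzoyl, and whether a free amine on the same saturated ring carbon would reach the limit.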